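Notes on chloro substitution of the phenoxy group

This account rests on a few compounds, and the source may have more. Where it says the series, first, only, none or still open, it means among the compounds named here.

Values in a functional assay on HL-60 cells (Homo sapiens) for antiproliferative activity, read by MTT assay, with a stated time of 72 h; on this read-out lower numbers stand for stronger inhibition and higher numbers for weaker inhibition:
compound 1 `NC1=NC2(CCOCC2)N(OCCCOc2ccccc2)C(N)=N1`: 2460 nM
compound 2 `CC(C)(C)c1ccc(OCCCON2C(N)=NC(N)=NC23CCSCC3)cc1`: 280 nM

Of these two values, compound 1 stands highest at 2460 nM. The number for compound 2 is lower, and the gap lies beyond the scatter. Among the measured compounds shown here, no measured pair differs in one place only, so the data give no direct size for a single change.

The next compound to be tested is compound 3 `NC1=NC2(CCOCC2)N(OCCCOc2ccc(Cl)cc2)C(N)=N1`. Relative to compound 1, it has chloro in place of hydrogen on an aromatic carbon, para to a large group: chloro in place of hydrogen on an aromatic carbon. A moderate step towards a lower number is expected in this assay, although a step within the scatter remains possible. For the measured compounds named here, the only guide to direction is compound 2 at 280 nM, and it is a loose one. The estimated change is a 2.7-fold lower number from compound 1 to compound 3 (0.44 log units; beyond the scatter). For compound 3 the estimate is 900 nM, with an expected range from 350 nM to 2300 nM.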

Compound 3, half-maximal inhibitory concentration: 330 nM
Estimate against measurement, compound 3: 2.7-fold (0.44 log units) above; the measured number lies below the stated range.
By their numbers in this assay, from the lowest: compounds 2 and 3 (each within the scatter of the next); then compound 1.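

In this assay, among the compounds shown here, the change from phenoxy to 4-chlorophenoxy gives a 7.5-fold lower number from compound 1 to compound 3 (0.87 log units; beyond the scatter) and is the first step that can be read for a single change. The step lies beyond the scatter, so this place on the aromatic ring, para to a large group, responds to one added chlorine atom while the rest of the compound stays the same. No measurement shown accounts for the size of this step.

On these data alone, it remains open whether fluoro, bromo, methyl or methoxy at this place would give a similar step, and whether chloro elsewhere on the ring would do so. Compound 2 differs from compound 3 in more than one place, so the contribution of its tert-butyl group cannot be read from these compounds.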